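Replacing the imidazolyl amide: what toxicity to expect

A few compounds are considered here, and "the series" means these few. Any claim that something is new, unique, unknown or untested is made for them only; others in the source may bear on it.

Measured compounds and their values in a toxicity assay on THP-1 cells (Homo sapiens) for inhibition; on this read-out higher numbers stand for lower toxicity in this test and lower numbers for higher toxicity in this test:
compound 1 `Cn1c(-c2cccc(C#N)c2)cnc1NC(=O)c1ncc[nH]1` gives > 50000 nM, which is a limit of the assay.
compound 2 `Cn1c(-c2ccccc2)cnc1NC(=O)c1ncc[nH]1` gives > 100000 nM, also a limit.
compound 3 `COc1ccccc1-c1cnc(NC(=O)c2ncc[nH]2)n1C` gives > 50000 nM, again a limit.

Compound 2 is thus known only as a limit, and the two other values are limits as well. The step that the two limits leave unreadable from compound 1 to compound 2 and the step that the two limits leave unreadable from compound 2 to compound 3 are both left unreadable by those limits. Compound 4 `Cc1ccc(C(=O)Nc2ncc(-c3ccccc3)n2C)cc1` differs from compound 2 by the change (4-methylphenyl in place of 1H-imidazol-2-yl on a carbonyl carbon). Among the measured compounds shown here, neither measured step touches the carbonyl carbon: both alter a group on an aromatic carbon, and both are unreadable, so no measured step bears directly on this change. For the measured compounds named here, the only guide is that all three compounds sit at limits, the limit of > 100000 nM in this assay, at which 1 of the 3 values shown sits, and (the limit of > 50000 nM in this assay, at which 2 of the 3 values shown sit). The expected step is an at least 1.6-fold lower number from compound 2 to compound 4 (0.22 log units; that floor lies within the scatter), none beyond the scatter. Compound 4 is therefore expected to give 60000 nM, within a range from 20000 nM to 150000 nM, most likely again reported as a limit.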

Compound 4, half-maximal cytotoxic concentration: > 50000 nM
Compound 4 ended at the assay's limit (the forecaster's own chance of this, stated with the estimate: 70%); the middle value does not contradict the limit.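

In this assay, compound 2 and compound 4 are both known only as limits, so the step between them cannot be read. The compounds shown leave open how toxic each one actually is, and whether 4-methylphenyl in place of 1H-imidazol-2-yl changes that at all.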